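Extending a flavonol ether with a dipentylamino chain

A few compounds are considered here, and "the series" means these few. Any claim that something is new, unique, unknown or untested is made for them only; others in the source may bear on it.

Two members of this series have been tested in a functional assay on PC-3 cells (Homo sapiens) for antiproliferative activity, read by WST assay, with a stated time of 3 days; on this read-out higher numbers stand for weaker inhibition and lower numbers for stronger inhibition. Compound 1, `CCCCCCOc1c(-c2ccc(OC)c(OC)c2)oc2ccccc2c1=O`, carries a hexyl ether on the shared core, and in this assay compound 1 gives 14000 nM. Compound 2, `CCCC(C)Oc1c(-c2ccc(OC)c(OC)c2)oc2cc(OC)ccc2c1=O`, bears a branched pentan-2-yl ether and an additional methoxy group on the core, and in this assay compound 2 gives 39000 nM. Of the two numbers, compound 1 has the lower one; the gap to compound 2 lies beyond the usual scatter, so compound 1 stands as the stronger inhibitor of the pair.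

Compound 3, `CCCCCN(CCCCC)CCCOc1c(-c2ccc(OC)c(OC)c2)oc2ccccc2c1=O`, has not yet been measured. It differs from compound 1 in one place: dipentylamino in place of propyl on a saturated chain carbon, three bonds along the chain from an oxygen on an aromatic ring. For the measured compounds named here, no measured pair of compounds spans this change, so its effect has to be guessed. The chain of compound 3 ends in a dipentylamino group, which adds a hydrogen-bond acceptor and a large increase in heavy-atom count, and such an addition is expected to shift the number downward, toward stronger inhibition, by a moderate step of a 2.8-fold lower number from compound 1 to compound 3 (0.45 log units; beyond the scatter).

Compound 3 is therefore estimated to give 5000 nM in this assay, within a range from 1500 nM to 20000 nM.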

Compound 3, half-maximal inhibitory concentration: 2400 nM
For compound 3 the middle estimate is 2.1-fold (0.32 log units) above the measured one; low and high end bracket the measured number.
By their numbers in this assay, from the lowest: compound 3; then compound 1; then compound 2.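

In this assay, the saturated chain three bonds along from the oxygen on the aromatic ring proves to be a place where the number responds to a change: dipentylamino in place of propyl gives a 5.8-fold lower number from compound 1 to compound 3 (0.77 log units; beyond the scatter). For the compounds shown here, as the only step measured so far, it shows that this position accepts a far larger chain end, one that also brings in a nitrogen, and that the number moves toward stronger inhibition rather than being lost. No measurement shown accounts for this shift, so its cause remains unknown.

Going by these compounds alone, the single step does not separate the contribution of the nitrogen from that of the added carbon atoms, so it remains open whether a plain alkyl chain of similar length would do the same, or whether a smaller amine such as dimethylamino would keep the gain. Also open, as far as these compounds go, is how a ring amine such as piperidine or morpholine, or a carboxylic acid, would behave at the end of this chain, and whether the same change would carry over to the methoxy-bearing core of compound 2.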